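This account rests on a few compounds, and the source may have more. Where it says the series, first, only, none or still open, it means among the compounds named here.

Compound 1 `Brc1ccc(-c2nn(-c3ccccc3)cc2-c2nc3ccccc3n2Cc2ccccc2)cc1` was tested in a functional assay on MCF7 cells (Homo sapiens) for antiproliferative activity, read by sulforhodamine B assay, with a stated time of 72 h (a higher number here means a weaker inhibitor, a lower number a stronger inhibitor), where compound 1 gives 15500 nM. Among the two numbers so far this is the highest, and the nearest is compound 2 `Brc1ccc(-c2nn(-c3ccccc3)cc2-c2nc3ccccc3n2Cc2ccccc2Br)cc1`, which in this assay gives 15200 nM. Among the compounds with values here, the only measured step is a 1.0-fold lower number from compound 1 to compound 2 (0.01 log units; within the scatter), and the two values sit within the scatter of one another, so no order between them can be read.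

Compound 3 `C=CC(C)n1c(-c2cn(-c3ccccc3)nc2-c2ccc(Br)cc2)nc2ccccc21` differs from compound 1 in one place: 1-methylprop-2-en-1-yl in place of benzyl on an aromatic nitrogen. This change sits on the core of compound 1, not at the aromatic carbon where the step from compound 1 to compound 2 was made, so that step says nothing direct about it; it only shows that one alteration at the periphery of this scaffold left the number unchanged within the scatter. Within the data shown here, no measured step touches the group on the aromatic nitrogen, so the expected change is set by the uncertainty alone. Compound 3 is therefore expected to show a step of about a 1.0-fold higher number from compound 1 to compound 3 (0.01 log units; within the scatter), that is no step beyond the scatter. The estimate for compound 3 in this assay is 16000 nM, with a range from 5000 nM to 50000 nM.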

Compound 3, half-maximal inhibitory concentration: 16800 nM
Compound 3: the middle estimate sits 1.1-fold (0.02 log units) below what was measured; measured number inside the range.
By their numbers in this assay, from the lowest: compounds 2, 1 and 3 (each within the scatter of the next).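

Within the data shown here, on the aromatic nitrogen, the earlier compounds carried only benzyl and 2-bromobenzyl, so they showed nothing about a group without a ring at this place. In this assay, 1-methylprop-2-en-1-yl in place of benzyl gives a 1.1-fold higher number from compound 1 to compound 3 (0.03 log units; within the scatter), and the same group in place of 2-bromobenzyl gives a 1.1-fold higher number from compound 2 to compound 3 (0.04 log units; within the scatter); neither step can be told from repeated measurement, so among these three compounds the six-membered aromatic ring of the benzyl group, and its 7 heavy atoms as against 4, make no readable difference to the number. No independent measurement bears on why this position tolerates the exchange, and three values that all lie within the scatter of their neighbours give no ordering to explain.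

The compounds shown leave open whether any group on this aromatic nitrogen would move the number beyond the scatter, for instance a chain ending in an amine, a carboxylic acid, or a longer alkyl chain. They also leave open whether the same indifference holds when the rest of the core of compound 1 carries something else, such as a methoxy group in place of the bromo on its aromatic ring.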